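The source may report more compounds than this note shows. Statements on the series, on what has been measured and on what is new or still open speak of the compounds shown alone.

Working notes on the series. Of the compounds shown here, three share one core and have been measured. Compound 1 `O=C(NCc1ccc(Cl)cc1Cl)C1CCN(Cc2ccn(-c3ccc(C(F)(F)F)cn3)c2)CC1` gives 444 nM in an assay on HEK293 cells for displacement of a labelled ligand from melanin-concentrating hormone receptor 1 (Homo sapiens); on this read-out lower numbers stand for stronger inhibition and higher numbers for weaker inhibition. Compound 2 `O=C(NCC1(O)CCCCC1)C1CCN(Cc2ccn(-c3ccc(C(F)(F)F)cc3)c2)CC1` gives 40 nM in this assay, and compound 3 `O=C(NCc1ccc(Cl)cc1O)C1CCN(Cc2ccn(-c3ccc(C(F)(F)F)cc3)c2)CC1` gives 22 nM in this assay. For the measured compounds named here, compound 3 thus holds the lowest of the three numbers; its nearest neighbour is compound 2, and the only single-place step into it, a 1.8-fold lower number from compound 2 to compound 3 (0.26 log units; within the scatter), stays within the scatter. Compound 1 lies furthest away, but compound 1 and compound 3 differ in more than one place, so their two values cannot be attributed to any one change.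

Compound 4 `O=C(NCc1c(O)cc(Cl)cc1Cl)C1CCN(Cc2ccn(-c3ccc(C(F)(F)F)cc3)c2)CC1` is obtained from compound 3 by the change (chloro in place of hydrogen on an aromatic carbon). Going by the values given here, no measured step isolates a chloro added to this aromatic ring; the one step in hand, a 1.8-fold lower number from compound 2 to compound 3 (0.26 log units; within the scatter), shows only that exchanging the whole group on the saturated chain carbon bound to the amide-type nitrogen moved the number little. Nothing in the present data argues for a shift beyond the scatter in either direction. The expected step from compound 3 to compound 4 is therefore a 1.4-fold higher number from compound 3 to compound 4 (0.13 log units; within the scatter), within the scatter. Compound 4 is estimated at 30 nM in this assay, with a range from 10 nM to 100 nM.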

Compound 4, half-maximal inhibitory concentration: 144 nM
Compound 4: the middle estimate sits 4.8-fold (0.68 log units) below what was measured, outside the stated range (above it).
By their numbers in this assay, from the lowest: compounds 3 and 2 (each within the scatter of the next); then compound 4; then compound 1.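

In this assay, for the compounds shown here, the step of a 6.5-fold higher number from compound 3 to compound 4 (0.82 log units; beyond the scatter) is the first single-place change to lie beyond the scatter: the added chloro, which sits on an aromatic carbon ortho to a large group and meta to both a chloro group and a hydroxy group, goes with a clearly higher number. The change of the whole group now also registers, since a 3.6-fold higher number from compound 2 to compound 4 (0.56 log units; beyond the scatter) lies beyond the scatter, whereas a 1.8-fold lower number from compound 2 to compound 3 (0.26 log units; within the scatter) stayed within it; on this read-out, 2,4-dichloro-6-hydroxyphenyl is therefore separated from 1-hydroxycyclohexyl, which 4-chloro-2-hydroxyphenyl was not. No available data bear on why the number rises with this change.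

From the compounds shown here alone, it remains open whether this rise is specific to chloro or would also follow fluoro, methyl or methoxy at the same aromatic carbon. Going by these compounds, it is equally open whether the step would keep its size with an amine or a methoxy group in place of the hydroxy group.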